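The source may hold more compounds than are shown below. What is called first, only, known or untested is meant among the compounds shown, and "the series" means these compounds.

Measured in a functional assay on MCF7 cells (Homo sapiens) for inhibition, read by WST assay, with a stated time of 72 h; on this read-out higher numbers stand for weaker inhibition and lower numbers for stronger inhibition:
- compound 1 `C[C@@H](CCCCCN/C(=N\C#N)Nc1ccncc1)C(=O)NOC1CCCCC1`: 1 nM
- compound 2 `N#C/N=C(\NCCCCC[C@@H](Cc1ccccc1)C(=O)NOC1CCCCC1)Nc1ccncc1`: 5.3 nM

Compound 2, at 5.3 nM, has the higher of the two numbers, so it inhibits more weakly than compound 1 at 1 nM, a gap beyond the scatter. Compound 3 `N#C/N=C(\NCCCCC[C@H](Cc1ccccc1)C(=O)NOC1CCCCC1)Nc1ccncc1` has not been measured. It differs from compound 2 only in its drawn configuration: the two compounds have the same atoms and bonds and differ only in configuration as drawn: 1 of 2 stereo elements differ; a stereocentre at a saturated chain carbon is drawn S in compound 2 and R in compound 3. Within the data shown here, no measured pair shows what such an inversion does, so no step beyond the scatter is expected in this assay, and no direction is favoured, though the uncertainty is wide. The expected change is a 1.3-fold lower number from compound 2 to compound 3 (0.12 log units; within the scatter). For compound 3 the estimate is 4 nM, with an expected range of 0.6 nM to 40 nM.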

Compound 3, half-maximal inhibitory concentration: 1.7 nM
The estimate for compound 3 lay 2.4-fold (0.37 log units) above the measured number, and the stated range covers the measured number.
By their numbers in this assay, from the lowest: compounds 1 and 3 (each within the scatter of the next); then compound 2.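

In this assay, the drawn configuration at this saturated chain carbon matters, with a 3.1-fold lower number from compound 2 to compound 3 (0.49 log units; beyond the scatter). That gap can be traced to the stereocentre alone, because nothing else separates the two compounds: the fact that compounds 2 and 3 differ only in the configuration as drawn. Setting phenyl in place of hydrogen on that carbon, in the R configuration, gives a 1.7-fold higher number from compound 1 to compound 3 (0.23 log units; within the scatter), so the added phenyl brings no change beyond the scatter in this configuration.

Open, going by these compounds, is whether an amine or a carboxylic acid in place of the phenyl would keep the number this low. Also open, on these data alone, is whether inverting this carbon has a similar effect with such groups.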